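The source may report more compounds than this note shows. Statements on the series, on what has been measured and on what is new or still open speak of the compounds shown alone.

Measured in a functional assay on MCF7 cells (Homo sapiens) for antiproliferative activity, read by luminescence and CellTiter-Glo, with a stated time of 48 h; a higher number here means a weaker inhibitor, a lower number a stronger inhibitor:
- compound 1 `O=C1C=CC[C@H](/C=C/c2ccc([N+](=O)[O-])cc2)O1`: 28800 nM
- compound 2 `O=C1C=CC[C@H](/C=C/C2CCCCC2)O1`: > 100000 nM
- compound 3 `O=C1C=CC[C@@H](/C=C/c2ccc([N+](=O)[O-])cc2)O1`: > 100000 nM

In this assay, compound 3 stands at > 100000 nM, which is a limit and not a number. Compound 4 `O=C1C=CC[C@@H](/C=C/c2ccc(F)cc2)O1` keeps the configuration of compound 3 as drawn and carries fluoro in place of nitro on an aromatic carbon.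

Within the data shown here, no measured step makes this swap, so its size is unknown. Among the measured compounds shown here, the one measured step, an at least 3.4-fold higher number from compound 1 to compound 3 (0.54 log units; beyond the scatter), comes with the fact that compounds 1 and 3 differ only in the configuration as drawn. It shows that configuration matters here, and compound 4 keeps the configuration of the poorer partner. No step beyond the scatter is therefore expected, only a result close to the limit. The expected step is a number no higher from compound 3 to compound 4 (the limit leaves the size open). For compound 4 the estimate is 100000 nM, with an expected range of 40000 nM to 250000 nM.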

Compound 4, half-maximal inhibitory concentration: > 100000 nM
Compound 4: a limit, no number (the forecaster's own chance of this, stated with the estimate: 70%); the middle value lies on the limit itself.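

In this assay, compound 3 and compound 4 each stand at a limit and not at a number, so the step between them cannot be read. The compounds shown leave open whether fluoro in place of nitro changes activity at all, in either configuration.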